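Urea series: aryl exchange on the amide-type nitrogen

The source may report more compounds than this note shows. Statements on the series, on what has been measured and on what is new or still open speak of the compounds shown alone.

compound 1 `O=C(Nc1cccc(-c2cnc3c(NC(=O)c4cc(Cl)cc(Cl)c4)nccn23)c1)c1ccc(Cl)c(C(F)(F)F)c1` 830 nM
compound 2 `O=C(Nc1cccc(-c2cnc3c(NC(=O)c4cc(Cl)cc(Cl)c4)nccn23)c1)Nc1ccc(F)cc1F` 620 nM

In a functional assay on HKE3 cells (Homo sapiens) for antiproliferative activity, read by CellTiter-Glo, with a stated time of 72 h (a higher number here means a weaker inhibitor, a lower number a stronger inhibitor), compound 1 gives 830 nM and compound 2 gives 620 nM. Among the compounds with values here, the single measured step, a 1.3-fold lower number from compound 1 to compound 2 (0.13 log units; within the scatter), alters linker and aryl group together, so compound 2 stands beside compound 1 inside the scatter, with no order between them. Compound 3 `O=C(Nc1cccc(-c2cnc3c(NC(=O)c4cc(Cl)cc(Cl)c4)nccn23)c1)Nc1ccc(Cl)c(C(F)(F)F)c1` keeps the linker of compound 2 and carries 4-chloro-3-(trifluoromethyl)phenyl in place of 2,4-difluorophenyl on an amide-type nitrogen. Within the data shown here, no measured pair isolates this aryl exchange on its own; the only step containing it was within the scatter. The expected step from compound 2 is a 1.2-fold lower number from compound 2 to compound 3 (0.09 log units; within the scatter). Compound 3 is estimated at 500 nM, range 200 nM to 1500 nM.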

Compound 3, half-maximal inhibitory concentration: 10000 nM
The estimate for compound 3 lay 20-fold (1.30 log units) below the measured number, outside the stated range (above it).
By their numbers in this assay, from the lowest: compounds 2 and 1 (each within the scatter of the next); then compound 3.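

In this assay, 4-chloro-3-(trifluoromethyl)phenyl in place of 2,4-difluorophenyl on an amide-type nitrogen gives a 16-fold higher number from compound 2 to compound 3 (1.21 log units; beyond the scatter), so this position does not accept every aryl group alike. The same aryl group on a carbonyl carbon does not carry this penalty: the change to (4-chloro-3-(trifluoromethyl)phenyl)amino gives a 12-fold higher number from compound 1 to compound 3 (1.08 log units; beyond the scatter), so in these three compounds the outcome depends on aryl group and linker together. No measurement available here accounts for the loss.

Going by these compounds, whether the 4-chloro group, the 3-(trifluoromethyl) group or their combination carries the loss remains open. On these data alone, how an unsubstituted phenyl or a 4-methoxyphenyl would read on this nitrogen also remains open.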